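From (methoxycarbonyl)methyl to 2-phenylethenyl on the carbonyl

This account rests on a few compounds, and the source may have more. Where it says the series, first, only, none or still open, it means among the compounds named here.

In a functional assay on NCI-H1975 cells (Homo sapiens) for inhibition, read by sulforhodamine B assay, tested at 10 uM (a lower number here means less inhibition, a higher number more inhibition at the concentration tested (going by the name of the read-out)), compound 1 `CN(C)c1ccc(C2CC(c3ccc(-n4cncn4)cc3)=NN2)cc1` gives -3.3%.
In this assay compound 2 `CN(C)c1ccc(C2CC(c3ccc(-n4ccnc4)cc3)=NN2)cc1` gives 0.1%.
In this assay compound 3 `COC(=O)CC(=O)N1N=C(c2ccc(N3CCN(C)CC3)cc2)CC1c1ccc(N(C)C)cc1` gives -2.2%.

Compound 3 sits second of the three numbers; its nearest neighbour is compound 1 and its furthest is compound 2, and both gaps lie within the scatter, so the three compounds are not told apart by these measurements. Compound 4 `CN1CCN(c2ccc(C3=NN(C(=O)/C=C/c4ccccc4)C(c4ccc(N(C)C)cc4)C3)cc2)CC1` differs from compound 3 in one place: 2-phenylethenyl in place of (methoxycarbonyl)methyl on a carbonyl carbon. Among the compounds with values here, the one measured step, a number 3.4 percentage points higher from compound 1 to compound 2 (within the scatter), exchanges a five-membered ring on an aromatic carbon and tells nothing about the group on the carbonyl carbon; no measured pair varies that group. Within the data shown here, with no step bearing on the change and all three numbers close to zero, compound 4 is expected to show no step beyond the scatter, a number 4.2 percentage points higher from compound 3 to compound 4 (within the scatter). Compound 4 is therefore estimated at 2% in this assay, with a range from -10% to 15%.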

Compound 4, a percentage reported as inhibition, at one concentration (the size of the read-out at that concentration, not a potency): 81%
The estimate for compound 4 lay 79 percentage points below the measured number; measured number above the stated range.
By their numbers in this assay, from the lowest: compounds 1, 3 and 2 (each within the scatter of the next); then compound 4.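

Putting 2-phenylethenyl in place of (methoxycarbonyl)methyl on the carbonyl carbon gives a number 83.2 percentage points higher from compound 3 to compound 4 (beyond the scatter) in this assay, so this position, on a carbonyl carbon whose other neighbour is an amide-type nitrogen in a ring, can carry a large change with the rest of compound 3 untouched. Within the data shown here, the earlier compounds, all within the scatter of one another, gave no sign of this, and the one earlier step concerned a different place. Nothing measured here accounts for the step.

The compounds shown leave open whether the double bond or the aromatic ring counts, as neither a saturated 2-phenylethyl group nor a plain phenyl on the carbonyl carbon appears among them. Also open, from the compounds shown here alone, is whether 2-phenylethenyl would do the same with 1H-imidazol-1-yl on the aromatic carbon instead of the 4-methylpiperazin-1-yl group.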